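This account rests on a few compounds, and the source may have more. Where it says the series, first, only, none or still open, it means among the compounds named here.

Measured compounds: compound 1 `Cn1c(-c2ccc(NC(=O)CCl)cc2)nc(-c2ccccc2)c1-c1ccccc1` gives 70% in a functional assay on MCF7 cells (Homo sapiens) for cytotoxicity, read by MTT assay, with a stated time of 24 h, tested at 80 ug/mL; a higher number here means a stronger effect of the compound at the concentration tested, a lower number a weaker effect; compound 2 `Cn1c(-c2ccc(NC(=O)CSC3=NCCS3)cc2)nc(-c2ccccc2)c1-c1ccccc1` gives 70%; compound 3 `CCN1CCN(CC(=O)Nc2ccc(-c3nc(-c4ccccc4)c(-c4ccccc4)n3C)cc2)CC1` gives 46.3%.

Compound 3 stands lowest of the three, set apart from both others beyond the scatter, as a number 23.7 percentage points lower from compound 1 to compound 3 (beyond the scatter) and a number 23.7 percentage points lower from compound 2 to compound 3 (beyond the scatter) show, while no change at the digits printed from compound 1 to compound 2 (within the scatter). Compound 4 `CN(C)/C=C/N1CCN(CC(=O)Nc2ccc(-c3nc(-c4ccccc4)c(-c4ccccc4)n3C)cc2)CC1` differs from compound 3 only on the amine nitrogen of its six-membered non-aromatic ring: 2-(dimethylamino)ethenyl in place of ethyl on an amine nitrogen in a ring. Among the compounds with values here, no measured step alters a group at that place; the steps that exist concern the carbon bound to the carbonyl, and they moved the number only modestly. The step of a number 0.3 percentage points lower from compound 3 to compound 4 (within the scatter) is therefore expected to stay within the scatter, and compound 4 is estimated at 46%, between 30% and 62%.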

Compound 4, a percentage reported as activity, at one concentration (the size of the read-out at that concentration, not a potency): 34.7%
Beside the measured number, compound 4's estimate is 11.3 percentage points above it; the measured number falls inside the stated range.
By their numbers in this assay, from the lowest: compound 4; then compound 3; then compounds 1 and 2 (each within the scatter of the next).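

Placing 2-(dimethylamino)ethenyl in place of ethyl on the amine nitrogen of the six-membered ring moves the number in this assay, with a number 11.6 percentage points lower from compound 3 to compound 4 (beyond the scatter), so this position, untouched by the earlier steps, affects the read-out. Within the data shown here, the gap to the earlier compounds widens, with a number 35.3 percentage points lower from compound 1 to compound 4 (beyond the scatter) and a number 35.3 percentage points lower from compound 2 to compound 4 (beyond the scatter), leaving compound 4 lowest of the four. Nothing available explains this drop.

Among these compounds, only two groups on that nitrogen can be compared here. On these data alone, it stays open how a methyl, an acetyl or a saturated 2-(dimethylamino)ethyl group there would read, and so whether the double bond or the added nitrogen matters.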